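The source may report more compounds than this note shows. Statements on the series, on what has been measured and on what is new or still open speak of the compounds shown alone.

The study starts from compound 1 `C=C(C(=O)Nc1ccccc1)C(F)(F)F`, which in an ADME assay for pharmacokinetics, read by LC-MS, in phosphate buffer, with a stated time of 120 min, at pH 7.4, tested at 1 uM, in the presence of a further agent that is not named here (on this read-out lower numbers stand for a shorter-lived compound and higher numbers for a longer-lived compound), gives 0.25 h. That is the only defined number among the results shown; the one other result is a limit rather than a number. Compound 2 `C/C=C/C(=O)Nc1ccccc1` returns in this assay only a limit, > 8.53 h, and so sits at the limit of > 8.53 h in this assay, at which 1 of the 2 values shown sits. For the measured compounds named here, compound 1 thus holds the single measured value and stands at the short-lived end of what has been reported. The step to the unmeasured compound 3 `C=C(C)C(=O)Nc1ccccc1` is methyl in place of trifluoromethyl on a double-bonded chain carbon bound to a carbonyl carbon. Going by the values given here, no pair of measured compounds differing in one place is available, so the size of this step rests on expectation alone. The step is expected to lengthen the half-life beyond the usual scatter, by a 16-fold higher number from compound 1 to compound 3 (1.20 log units; beyond the scatter). Compound 3 is estimated in this assay at 4 h, with a range from 1 h to 8.5 h.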

Compound 3, half-life: > 8.53 h
Compound 3 gave a limit, no number; the forecaster's own chance of this, stated with the estimate: 35%; at least 2.1-fold (0.32 log units) between middle value and limit.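

In this assay, for the compounds shown here, methyl in place of trifluoromethyl on a double-bonded chain carbon bound to a carbonyl carbon gives an at least 34-fold higher number from compound 1 to compound 3 (1.53 log units; beyond the scatter), the first readable step in this set and one that lies beyond the scatter. This single change at this place is enough to take the shared core from a defined short half-life to a limit rather than a number: the limit of > 8.53 h in this assay, at which 2 of the 3 values shown sit. The step between compound 2 and compound 3 cannot be read, as both values are limits.

From the compounds shown here alone, how far the half-life of compound 3 lies past its limit remains open, and so does the full size of the step. Also open, going by these compounds, is whether a nitrile or an ethyl at this place would stay at the limit or give a half-life closer to that of compound 1.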